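A few compounds are considered here, and "the series" means these few. Any claim that something is new, unique, unknown or untested is made for them only; others in the source may bear on it.

Measured so far in a functional assay on A549 cells (Homo sapiens) for antiproliferative activity, read by MTT assay; on this read-out higher numbers stand for weaker inhibition and lower numbers for stronger inhibition:
compound 1, `C#CCN(c1nc2ccc(F)cc2s1)c1nc2ccc(OC)cc2s1`: 24500 nM
compound 2, `COc1ccc2nc(N(Cc3cc(-c4ccccc4F)no3)c3nc4ccc(F)cc4s3)sc2c1`: 51800 nM
compound 3, `FC(F)(F)Sc1ccc(-c2cc(CN(c3ncccn3)c3nc4ccccc4s3)on2)cc1`: 29800 nM

Compound 3 stands second highest of the three numbers. Its nearest neighbour is compound 1, within the scatter, and the furthest, compound 2, also lies within the scatter, so the three values do not separate from one another.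

Compound 4 is `COc1ccc(-c2cc(CN(c3ncccn3)c3nc4ccccc4s3)on2)cc1`, not yet measured. From compound 3 it differs by methoxy in place of (trifluoromethyl)sulfanyl on an aromatic carbon. Among the compounds with values here, no pair of measured compounds shows this change, so no step size is known from the series. In this assay a step no larger than the scatter is expected, in either direction. Compound 4 is expected to give 35000 nM, with a range of 12000 nM to 100000 nM. The implied step is estimated as a 1.2-fold higher number from compound 3 to compound 4 (0.07 log units; within the scatter).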

Compound 4, half-maximal inhibitory concentration: 30500 nM
The estimate for compound 4 lay 1.1-fold (0.06 log units) above the measured number, within the range that was stated.
By their numbers in this assay, from the lowest: compounds 1, 3, 4 and 2 (each within the scatter of the next, the first and the last beyond it).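

In this assay, within the data shown here, replacing 4-((trifluoromethyl)sulfanyl)phenyl with 4-methoxyphenyl gives a 1.0-fold higher number from compound 3 to compound 4 (0.01 log units; within the scatter), the first step that can be read at a single place. On this aromatic carbon, para to a large group, the smaller methoxy thus stands in for (trifluoromethyl)sulfanyl without separating the two compounds. No measurement bears on why this step is so small.

Going by these compounds, whether an amine or a carboxylic acid on this carbon would also stay within the scatter remains open. So does whether the same change reads alike on other cores.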